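Trifluoromethyl Across Two Cores in a Mouse Assay

The source may hold more compounds than are shown below. What is called first, only, known or untested is meant among the compounds shown, and "the series" means these compounds.

Compound 1 `c1ccc(N2N=NCC2c2ccncc2)cc1` and compound 2 `FC(F)(F)c1ccc(N2N=NCC2c2ccncc2)cc1` share one core, while compound 3 `c1ccc(-n2nncc2-c2cccnc2)cc1` and compound 4 `FC(F)(F)c1ccc(-n2nncc2-c2cccnc2)cc1` share another; the difference between the two cores is not broken down here. In a functional assay on the whole organism with Mus musculus as the target (a lower number here means that less compound is needed, a higher number that more compound is needed for the effect), compound 1 gives 107 mg/kg, compound 2 gives 421 mg/kg and compound 3 gives 39.7 mg/kg. The change from compound 1 to compound 2, (trifluoromethyl in place of hydrogen on an aromatic carbon), brought a 3.9-fold higher number from compound 1 to compound 2 (0.59 log units; beyond the scatter). Compound 4 carries the same change against compound 3, (trifluoromethyl in place of hydrogen on an aromatic carbon), in a place described in the same words. Among the measured compounds shown here, because the only measured instance of this change is a 3.9-fold higher number from compound 1 to compound 2 (0.59 log units; beyond the scatter), a step of similar size is expected here as well, a 3.5-fold higher number from compound 3 to compound 4 (0.55 log units; beyond the scatter). Compound 4 is therefore estimated at 140 mg/kg in this assay, with a range expected from 60 mg/kg to 400 mg/kg.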

Compound 4, dose for half-maximal effect: 90.5 mg/kg
For compound 4 the middle estimate is 1.5-fold (0.19 log units) above the measured one, within the range that was stated.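

In this assay, the trifluoromethyl change again raised the number, giving a 2.3-fold higher number from compound 3 to compound 4 (0.36 log units; beyond the scatter). Set side by side, the two steps point the same way and do not differ in size beyond the scatter: the same change on two cores in this assay, a 3.9-fold higher number (0.59 log units; beyond the scatter) from compound 1 to compound 2 and a 2.3-fold higher number (0.36 log units; beyond the scatter) from compound 3 to compound 4, 1.7-fold (0.24 log units) apart, within the scatter of two such steps. Among the compounds shown here, this shows that the change carried over between these two cores, but it rests on only two pairs and shows neither why the number rises nor how the change would behave on any other core.

The compounds shown leave open whether a different group on that aromatic carbon, such as a methoxy group, a nitrile or a single fluorine, would shift the number in the same way. They also leave open whether trifluoromethyl would give a similar step elsewhere on the ring.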